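The source may hold more compounds than are shown below. What is called first, only, known or untested is meant among the compounds shown, and "the series" means these compounds.

Working notes on a short series of cytotoxicity measurements. The set comprises compound 1 `COc1cc(C(=O)/C=C/c2ccc3c(c2)B(O)OC3)cc(OC)c1OC`, compound 2 `O=C(/C=C/c1ccc2c(c1)B(O)OC2)c1ccc(OCc2ccccc2)cc1`, and compound 3 `CC(=O)Nc1ccc(C(=O)/C=C/c2ccc3c(c2)B(O)OC3)cc1`, which has not yet been measured.

In an ADME assay on L929 cells (Mus musculus) for cytotoxicity, read by resazurin assay, with a stated time of 72 h (on this read-out higher numbers stand for weaker inhibition and lower numbers for stronger inhibition), compound 1 returns only a limit of the assay, > 10 ug/mL. In this assay compound 2 likewise returns only a limit, > 10 ug/mL. Both values therefore sit at the limit of > 10 ug/mL in this assay, at which 2 of the 2 values shown sit, and compound 2 stands nowhere below that ceiling; no numerical value is available for any measured compound.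

The change to compound 3 is acetamido in place of benzyloxy on an aromatic carbon. Going by the values given here, with no measured step available, the expected step in this assay is a step that the limit leaves unreadable from compound 2 to compound 3, none beyond the scatter. Compound 3 is expected to give 15 ug/mL (7 ug/mL to 40 ug/mL), most likely again reported as a limit.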

Compound 3, half-maximal inhibitory concentration: > 10 ug/mL
Compound 3: no number, only a limit; the forecaster's own chance of this, stated with the estimate: 75%; the middle value lies beyond the limit too.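

Going by these compounds alone, compound 2 and compound 3 both return only limits in this assay, so no step between them can be read. The compounds shown leave open whether acetamido in place of benzyloxy changes cytotoxicity at all.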